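Extending the ethyl of compound 1 toward a 3-chlorobenzyl

The compounds below may be only part of what the source reports. "The series", "measured", "known", "first", "only" and "open" are said of these compounds alone.

Measured compounds:
compound 1 `CCn1c(CN2CCN(C(=O)C3CC3)CC2)nc2ccccc21`: 20.8%
compound 2 `CC(=O)N1CCN(Cc2nc3ccccc3n2Cc2cccc(C)c2)CC1`: 70.3%
compound 3 `Cc1cccc(Cn2c(CN3CCN(C(=O)C(C)C)CC3)nc3ccccc32)c1`: 87.2%

In an assay on isolated protein for inhibition of aldehyde dehydrogenase 1A1 (Homo sapiens), read by spectrophotometry, tested at 10 uM (on this read-out higher numbers stand for more inhibition at the one concentration tested (going by the name of the read-out) and lower numbers for less inhibition), compound 1 gives 20.8%, the lowest of the three numbers; compound 2 stands higher at 70.3%, and compound 3 higher still at 87.2%, both gaps beyond the scatter. Among the compounds with values here, the only single-place step recorded is a number 16.9 percentage points higher from compound 2 to compound 3 (beyond the scatter), which concerns the acyl end of the shared core and not the change considered here.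

Compound 4 `O=C(C1CC1)N1CCN(Cc2nc3ccccc3n2Cc2cccc(Cl)c2)CC1` differs from compound 1 by 3-chlorophenyl in place of methyl on a saturated chain carbon bound to an aromatic nitrogen. Within the data shown here, no measured pair isolates this change. What the numbers do show is that compound 2 and compound 3, each carrying a benzyl on the aromatic nitrogen, sit far above compound 1, which carries ethyl there, although they also differ from compound 1 at the carbonyl. Compound 1 gives 20.8%, while of the two benzyl-bearing compounds compound 2 gives 70.3% and compound 3 gives 87.2%. On that basis a sizeable rise is expected for compound 4 in this assay, namely a number 51.2 percentage points higher from compound 1 to compound 4 (beyond the scatter). Compound 4 is therefore estimated at 72%, with a likely range from 45% to 92%.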

Compound 4, a percentage reported as inhibition, at one concentration (the size of the read-out at that concentration, not a potency): 71.6%
Beside the measured number, compound 4's estimate is 0.4 percentage points above it, and the stated range covers the measured number.
By their numbers in this assay, from the lowest: compound 1; then compounds 2 and 4 (each within the scatter of the next); then compound 3.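

With the cyclopropyl carbonyl end held the same, the change from ethyl to 3-chlorobenzyl on the aromatic nitrogen can now be read on its own in this assay. Within the data shown here, it gives a number 50.8 percentage points higher from compound 1 to compound 4 (beyond the scatter), so this position alone carries a large step, which the earlier compounds could not show because each benzyl-bearing compound also differed from compound 1 at the carbonyl. Nothing measured here accounts for the size of this step.

The compounds shown leave open whether the chlorine contributes, since a plain benzyl on the same cyclopropyl carbonyl compound would be needed to separate it from the added aromatic ring. They also leave open whether a longer saturated chain such as n-butyl, with no aromatic ring, would produce a similar rise.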